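Benzyloxy in Place of Hydrogen on the Aromatic Carbon

The source may hold more compounds than are shown below. What is called first, only, known or untested is meant among the compounds shown, and "the series" means these compounds.

Compound 1, `O=C(O)c1cnc(-c2ccccc2)[nH]c1=O`, stands together with compound 2, `Nc1ccccc1-c1ncc(C(=O)O)c(=O)[nH]1`, at the high end of the three numbers in a functional assay on the whole organism (strain Sprague-Dawley) for inhibition, with Rattus norvegicus as the target, with a stated time of 10 min (a lower number here means that less compound is needed, a higher number that more compound is needed for the effect), where compound 1 gives 50 mg/kg and compound 2 gives 50 mg/kg. Compound 3, `COc1ccccc1-c1ncc(C(=O)O)c(=O)[nH]1`, gives 10 mg/kg. The step of no change at the digits printed from compound 1 to compound 2 (within the scatter) lies within the scatter, whereas a 5.0-fold lower number from compound 1 to compound 3 (0.70 log units; beyond the scatter) and a 5.0-fold lower number from compound 2 to compound 3 (0.70 log units; beyond the scatter) each go beyond it.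

The compound under consideration is compound 4, `O=C(O)c1cnc(-c2ccccc2OCc2ccccc2)[nH]c1=O`, which differs from compound 1 as follows: benzyloxy in place of hydrogen on an aromatic carbon. Of the measured steps, a 5.0-fold lower number from compound 1 to compound 3 (0.70 log units; beyond the scatter) bears most directly on this change, since methoxy and benzyloxy both replace hydrogen on that aromatic carbon; the step of a 5.0-fold lower number from compound 2 to compound 3 (0.70 log units; beyond the scatter) only confirms that the amino analogue and the parent sit level. Going by the values given here, a modest lowering is therefore expected for compound 4, with a wider range than usual, as benzyloxy is a larger group than methoxy and no measured compound carries one. The expected step is a 3.3-fold lower number from compound 1 to compound 4 (0.52 log units; beyond the scatter), and compound 4 is estimated to give about 15 mg/kg, between 5 mg/kg and 50 mg/kg.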

Compound 4, dose for 50% inhibition: 5 mg/kg
Compound 4: middle estimate off by 3.0-fold (0.48 log units), on the high side, within the range that was stated.
By their numbers in this assay, from the lowest: compounds 4 and 3 (each within the scatter of the next); then compounds 1 and 2 (each within the scatter of the next).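

In this assay, a group carrying a six-membered aromatic ring of carbon only is accepted on this aromatic carbon, with a 10-fold lower number from compound 1 to compound 4 (1.00 log units; beyond the scatter) and a 10-fold lower number from compound 2 to compound 4 (1.00 log units; beyond the scatter), so the lowering seen with methoxy is not confined to that small group, although amino in compound 2 does not share it. Adding phenyl to the saturated chain carbon of the methoxy group gives a 2.0-fold lower number from compound 3 to compound 4 (0.30 log units; within the scatter), so compound 3 and compound 4 cannot be told apart in this measurement, and the extra ring brings no separable gain or loss. No supporting evidence is available to explain these results.

The compounds shown leave open whether a longer chain, such as phenethyloxy, would keep this level. They also leave open how a benzyloxy group bearing a carboxylic acid or an amine on its ring would behave at this position.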